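Chalcone series: fluoro for hydrogen on the styryl ring

The source may report more compounds than this note shows. Statements on the series, on what has been measured and on what is new or still open speak of the compounds shown alone.

Measured compounds:
compound 1, `COc1cccc(/C=C/C(=O)c2c(OC)cc(OC)cc2OC)c1`, 43%
compound 2, `COc1cc(OC)c(C(=O)/C=C/c2ccccc2)c(OC)c1`, 37%

Both measured compounds carry the same trimethoxy-substituted ketone side; they differ only on the other ring. In a functional assay on MDA-MB-231 cells (Homo sapiens), read by fluorescence and BrdU incorporation, with a stated time of 48 h, tested at 10 uM (a higher number here means a weaker effect of the compound at the concentration tested, a lower number a stronger effect), compound 1 gives 43%, and compound 2 gives 37%. Going by the values given here, the single step between them, a number 6 percentage points lower from compound 1 to compound 2 (within the scatter), stays within the scatter, so compound 2 stands level with compound 1 on the numbers so far; nothing in the data separates the two.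

Compound 3, `COc1cc(OC)c(C(=O)/C=C/c2ccc(F)cc2)c(OC)c1`, is not yet measured. It differs from compound 2 by fluoro in place of hydrogen on an aromatic carbon. Among the compounds with values here, no measured step touches a fluoro group, so the only guidance is the one step recorded on this ring, the removal of a methoxy group, which moved the read-out by an amount within the scatter. On that basis a small substituent change on the same ring is expected to leave this assay without a step beyond the scatter; the expected step is no change at the digits printed from compound 2 to compound 3 (within the scatter).

For compound 3 the estimate in this assay is 37%, with a range from 22% to 52%.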

Compound 3, a percentage reported as activity, at one concentration (the size of the read-out at that concentration, not a potency): 43%
For compound 3 the middle estimate is 6 percentage points below the measured one, within the range that was stated.
By their numbers in this assay, from the lowest: compounds 2, 1 and 3 (each within the scatter of the next).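

In this assay, phenyl to 4-fluorophenyl gives a number 6 percentage points higher from compound 2 to compound 3 (within the scatter), so a fluoro group on an aromatic carbon para to a large group leaves this compound level with the parent carrying only hydrogen there. The direct comparison of the two substituted rings gives no change at the digits printed from compound 1 to compound 3 (within the scatter), which places 4-fluorophenyl level with 3-methoxyphenyl and adds a second substituent type and a second place on this ring to the changes that stay within the scatter. No further data bear on this result.

The compounds shown leave open whether an amine or a carboxylic acid on the same aromatic carbon would move the read-out beyond the scatter, and whether fluoro on another carbon of this ring would read as the 4-fluorophenyl compound does. As far as these compounds go, the trimethoxy-substituted ketone side is the same in all three compounds, so what a change on that side would do also remains open.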